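The compounds below may be only part of what the source reports. "The series", "measured", "known", "first", "only" and "open" are said of these compounds alone.

Within the data shown here, compound 1 `C[C@@H](NC(=O)Nc1ccc(C(C)(C)C)cc1)c1ccccc1` is one of three compounds measured in an ADME assay on the whole organism with Oryza sativa as the target, tested at 10 uM; on this read-out lower numbers stand for a stronger effect and higher numbers for a weaker effect at the one concentration tested. In that test compound 1 gives 53%, the lowest of the three numbers and so the strongest effect among them. Compound 2 `C[C@H](NC(=O)Nc1ccc(C(C)(C)C)cc1)c1ccccc1` gives 64%, and the step of a number 11 percentage points higher from compound 1 to compound 2 (beyond the scatter) rests only on (the fact that compounds 1 and 2 differ only in the configuration as drawn). Compound 3 `C[C@H](NC(=O)Nc1cccc(C(F)(F)F)c1)c1ccccc1` gives 92%; it differs from compound 1 in more than one place, so the two values can only be set side by side. Compound 4 `C[C@@H](NC(=O)Nc1ccc(I)cc1)c1ccccc1` has not yet been measured. It differs from compound 1 by iodo in place of tert-butyl on an aromatic carbon. Among the measured compounds shown here, no measured step involves an exchange of this kind: the only measured step is a change of configuration, and compound 3 changes both the configuration and the group on its aromatic ring. For the measured compounds named here, there is therefore no step to lean on, and the expectation is a shift of no clear direction, likely within the scatter around the value of compound 1. Compound 4 is expected to give about 60%, between 38% and 82%. That would mean an expected step of a number 7 percentage points higher from compound 1 to compound 4 (within the scatter).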

Compound 4, a percentage reported as activity, at one concentration (the size of the read-out at that concentration, not a potency): 85%
Beside the measured number, compound 4's estimate is 25 percentage points below it; the measured number lies above the stated range.
By their numbers in this assay, from the lowest: compound 1; then compound 2; then compounds 4 and 3 (each within the scatter of the next).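

In this assay, the exchange of tert-butyl for iodo on this aromatic carbon gives a number 32 percentage points higher from compound 1 to compound 4 (beyond the scatter), the first measured sign that the group at this place shapes the read-out. Of these two groups, tert-butyl goes with the stronger effect, and the single iodine atom that takes the place of its four carbons leaves much less of that effect. Nothing measured here explains what in this exchange produces the step.

Open, going by these compounds, is how other groups on this aromatic carbon would read, such as a methoxy group, an amine or a carboxylic acid, and whether chloro or bromo would sit nearer to compound 1 or to compound 4. Also open, on these data alone, is whether the same exchange would give a similar step in the configuration of compound 2.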